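A few compounds are considered here, and "the series" means these few. Any claim that something is new, unique, unknown or untested is made for them only; others in the source may bear on it.

The measured compounds:

Compound 1, `CCc1ccc(-c2ccc(NC3=CC(=O)c4ncncc4C3=O)cc2)cc1`, gives in a functional assay on MIA PaCa-2 cells (Homo sapiens) for cytotoxicity, read by MTT assay, with a stated time of 72 h (a lower number here means a stronger inhibitor, a higher number a weaker inhibitor), a value of 1500 nM.
Compound 2, `O=C1C(Nc2cccc(-c3ccccc3)c2)=CC(=O)c2ncncc21`, gives in this assay a value of 2400 nM.
Compound 3, `O=C1C(Nc2ccc(C3CCCCC3)cc2)=CC(=O)c2ncncc21`, gives in this assay a value of 1200 nM.

Compound 3 has the lowest of the three numbers, but its gaps to compound 1 and to compound 2 both lie within the scatter, so no order among the three can be claimed. Within the data shown here, the only step with a single change, a 1.3-fold lower number from compound 1 to compound 3 (0.10 log units; within the scatter), also stayed within the scatter.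

Compound 4, `O=C1C(Nc2ccc(N3CCCCC3)cc2)=CC(=O)c2ncncc21`, differs from compound 3 in one place: piperidin-1-yl in place of cyclohexyl on an aromatic carbon. Among the measured compounds shown here, no measured step exchanges a carbon ring for a nitrogen-containing ring at this aromatic carbon, so that step is the only guide, and it shows that a change of similar size at the same place left the number within the scatter. Compound 4 is therefore expected to give a number close to that of compound 3, with the step of a 1.3-fold higher number from compound 3 to compound 4 (0.10 log units; within the scatter) expected to stay within the scatter. Compound 4 is estimated at 1500 nM, with a range from 500 nM to 4500 nM.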

Compound 4, half-maximal inhibitory concentration: 2400 nM
Estimate against measurement, compound 4: 1.6-fold (0.20 log units) below, and the stated range covers the measured number.
By their numbers in this assay, from the lowest: compounds 3, 1, 2 and 4 (each within the scatter of the next).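

With a 2.0-fold higher number from compound 3 to compound 4 (0.30 log units; within the scatter) in this assay, piperidin-1-yl, which brings a ring nitrogen and a hydrogen-bond acceptor that cyclohexyl lacks, takes the place of cyclohexyl on this aromatic carbon without the number leaving the scatter. The second new comparison, a 1.6-fold higher number from compound 1 to compound 4 (0.20 log units; within the scatter), also stays within the scatter, so 4-ethylphenyl, cyclohexyl and piperidin-1-yl cannot be told apart at this position in this cell assay. Nothing measured alongside these numbers speaks to what lies behind them. From the compounds shown here alone, whether a morpholin-4-yl ring, a carboxylic acid or a free amine on this aromatic carbon would carry the number beyond the scatter remains open. Also open, going by these compounds, is whether a much smaller group here, such as methoxy or a single fluorine, would do the same.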